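Swapping the indazole for a chloroindole on the shared core

The compounds below may be only part of what the source reports. "The series", "measured", "known", "first", "only" and "open" are said of these compounds alone.

Compound 2 `NC(=O)c1ccc2c(c1)CCOC2CCN1CC=C(c2[nH]nc3cc(F)ccc23)CC1` is measured in an assay on cells for binding affinity to 5-hydroxytryptamine receptor 1D (Homo sapiens), read by radioligand binding (on this read-out lower numbers stand for stronger inhibition and higher numbers for weaker inhibition), and gives 24 nM. Among the three compounds measured, this is the second highest number: compound 1 `NC(=O)c1ccc2c(c1)CCOC2CCN1CC=C(c2cccc3ccccc23)CC1` gives 5.4 nM, and compound 3 `C[C@H]1CC(c2c[nH]c3cc(F)ccc23)CCN1CCC1OCCc2cc(C(N)=O)ccc21` gives 28 nM, a value within the scatter of compound 2. Among the compounds with values here, the one directly comparable step, a 4.4-fold higher number from compound 1 to compound 2 (0.65 log units; beyond the scatter), shows that replacing naphthalen-1-yl with the indazole weakened binding modestly. Compound 4 `NC(=O)c1ccc2c(c1)CCOC2CCN1CC=C(c2c[nH]c3cc(Cl)ccc23)CC1` carries the change (6-chloro-1H-indol-3-yl in place of 6-fluoro-2H-indazol-3-yl on a double-bonded ring carbon). Within the data shown here, no measured step isolates this swap; compound 3, which also bears an indole, differs from compound 2 in further places, so it only hints that an indole is tolerated. A modest move toward lower numbers is therefore expected for compound 4, a 2.0-fold lower number from compound 2 to compound 4 (0.30 log units; within the scatter), giving an estimate of 12 nM, with a range from 4 nM to 40 nM.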

Compound 4, inhibition constant: 145 nM
Compound 4: the middle estimate sits 12-fold (1.08 log units) below what was measured; the whole stated range lies below it.
By their numbers in this assay, from the lowest: compound 1; then compounds 2 and 3 (each within the scatter of the next); then compound 4.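

In this assay, this position proves sensitive even between two groups of the same heavy-atom count: 6-chloro-1H-indol-3-yl in place of 6-fluoro-2H-indazol-3-yl gives a 6.0-fold higher number from compound 2 to compound 4 (0.78 log units; beyond the scatter). Set against naphthalen-1-yl, the same group gives a larger change, a 27-fold higher number from compound 1 to compound 4 (1.43 log units; beyond the scatter), which places these three groups in a clear order at this ring carbon. Nothing available here accounts for these differences.

The halogen and the ring atoms changed together, so the step cannot separate their contributions. From the compounds shown here alone, how a simple amine or a carboxylic acid would read on this double-bonded ring carbon remains open.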